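Swapping the Aryl Group of Compound 3 for 3-Chlorophenyl

A few compounds are considered here, and "the series" means these few. Any claim that something is new, unique, unknown or untested is made for them only; others in the source may bear on it.

Measured in a functional assay on MCF7 cells (Homo sapiens) for cytotoxicity, read by MTT assay, with a stated time of 72 h; on this read-out higher numbers stand for weaker inhibition and lower numbers for stronger inhibition:
- Compound 1 `CN(C)c1ccc(C=C2C(=O)N(c3ccc(Cl)cc3)N(c3ccc(Cl)cc3)C2=O)cc1`: > 128000 nM (a limit of the assay, not a number)
- Compound 2 `O=C1C(=Cc2ccc(F)cc2)C(=O)N(c2ccc(Cl)cc2)N1c1ccc(Cl)cc1`: 31400 nM
- Compound 3 `COc1cccc(C=C2C(=O)N(c3ccc(Cl)cc3)N(c3ccc(Cl)cc3)C2=O)c1O`: 26700 nM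

Compound 3 gives 26700 nM and sits level with compound 2, which gives 31400 nM. Compound 1 stands at a limit, (the limit of > 128000 nM in this assay, at which 1 of the 3 values shown sits).

Compound 4 `O=C1C(=Cc2cccc(Cl)c2)C(=O)N(c2ccc(Cl)cc2)N1c1ccc(Cl)cc1` carries 3-chlorophenyl in place of 2-hydroxy-3-methoxyphenyl on a double-bonded chain carbon bound to a double-bonded ring carbon.

The closest guide is an exchange at the same carbon, 2-hydroxy-3-methoxyphenyl in place of 4-fluorophenyl, which gave a 1.2-fold lower number from compound 2 to compound 3 (0.07 log units; within the scatter). Two other steps, an at least 4.0-fold lower number from compound 1 to compound 2 (0.61 log units; beyond the scatter) and an at least 4.7-fold lower number from compound 1 to compound 3 (0.68 log units; beyond the scatter), start from the limit, so they give only a minimum size, and both leave 4-(dimethylamino)phenyl. Neither exchange resembles the one at hand, so no step beyond the scatter is expected in this assay.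

The expected step is a 1.0-fold higher number from compound 3 to compound 4 (0.00 log units; within the scatter). For compound 4 the estimate is 27000 nM, with an expected range of 10000 nM to 70000 nM.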

Compound 4, half-maximal inhibitory concentration: 18300 nM
Beside the measured number, compound 4's estimate is 1.5-fold (0.17 log units) above it; the range from low to high includes it.
By their numbers in this assay, from the lowest: compounds 4, 3 and 2 (each within the scatter of the next). At a limit, above all of these: compound 1.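

In this assay, 3-chlorophenyl has none of the hydrogen-bond donors or acceptors of 2-hydroxy-3-methoxyphenyl, yet the exchange gives a 1.5-fold lower number from compound 3 to compound 4 (0.16 log units; within the scatter), so at this carbon those features of compound 3 are not required to keep its level. The exchange of 4-fluorophenyl for 3-chlorophenyl gives a 1.7-fold lower number from compound 2 to compound 4 (0.23 log units; within the scatter), which makes a third aryl group at this carbon that cannot be told apart from the others shown, apart from 4-(dimethylamino)phenyl. Compound 1 stands at a limit, not a number, so this change can be sized only as a minimum, an at least 6.9-fold lower number from compound 1 to compound 4 (0.84 log units; beyond the scatter), and that limit is the only such value here: the limit of > 128000 nM in this assay, at which 1 of the 4 values shown sits.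

Still open, from the compounds shown here alone, is whether 2-chlorophenyl or 4-chlorophenyl at this carbon would match 3-chlorophenyl. Also open, going by these compounds, is whether a carboxylic acid or a nitrile on this ring would move the number beyond the scatter.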